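The source may report more compounds than this note shows. Statements on the series, on what has been measured and on what is new or still open speak of the compounds shown alone.

Measured so far:
compound 1 `CCOC(=O)c1ccc(-c2nn(Cc3ccc(Cl)cc3)c3ccccc23)cc1`: > 10000 nM
compound 2 `CCOC(=O)c1ccc(-c2nn(Cc3cccnc3)c3ccccc23)cc1`: > 10000 nM

In a functional assay on cells (Platelet, Homo sapiens) for inhibition (on this read-out lower numbers stand for stronger inhibition and higher numbers for weaker inhibition), compound 1 gives only a limit of the assay, not a number. Compound 2 likewise gives only a limit. The step that the two limits leave unreadable from compound 1 to compound 2 is therefore not readable, both values sitting at the limit of > 10000 nM in this assay, at which 2 of the 2 values shown sit. Compound 3 `CCCCn1nc(-c2ccc(C(=O)OCC)cc2)c2ccccc21` differs from compound 1 by propyl in place of 4-chlorophenyl on a saturated chain carbon bound to an aromatic nitrogen. Among the compounds with values here, no measured step gives a size for this change, and the one step available carries no size itself. Compound 3 is expected to remain at the limit as well, the estimate being 30000 nM, between 8000 nM and 200000 nM, which corresponds to the expected step that the limit leaves unreadable from compound 1 to compound 3.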

Compound 3, half-maximal inhibitory concentration: > 10000 nM
Compound 3: a limit, no number; the forecaster's own chance of this, stated with the estimate: 85%; the middle value does not contradict the limit.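

In this assay, no step can be read among compound 1, compound 2 and compound 3, as each value is only a limit: the limit of > 10000 nM in this assay, at which 3 of the 3 values shown sit.

The compounds shown leave open how strongly each inhibits and whether the group on the saturated chain carbon affects inhibition.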